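This account rests on a few compounds, and the source may have more. Where it says the series, first, only, none or still open, it means among the compounds named here.

Measured so far in an ADME assay on HepG2 cells (Homo sapiens) for cytotoxicity, read by luminescence, CellTiter-Glo and ATP content, with a stated time of 72 h; on this read-out lower numbers stand for an effect already at smaller amounts and higher numbers for an effect only at larger amounts of compound:
- compound 1, `COc1cccc(CNCCCNc2ccnc3cc(Oc4ccc(Cl)cc4)ccc23)c1O`: 5700 nM
- compound 2, `COc1ccc(F)cc1CNCCCNc1ccnc2cc(CC(C)C)ccc12`: 2900 nM
- compound 3, `c1ccc(CCc2ccc3c(NCCCNCc4ccco4)ccnc3c2)cc1`: 16000 nM

Compound 1 stands second highest of the three numbers. Compound 2 is its nearest neighbour, and the two values lie within the scatter of each other, so no order between them is claimed. Compound 3 gives the highest number of the set; its gap to compound 1 lies beyond the scatter.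

Compound 4, `COc1cccc(CNCCCNc2ccnc3cc(Cc4cccc(C(F)(F)F)c4)ccc23)c1O`, has not yet been measured in this assay. It differs from compound 1 in one place: 3-(trifluoromethyl)benzyl in place of 4-chlorophenoxy on an aromatic carbon. Within the data shown here, no measured pair shares this change, so the expectation rests only on the three values above, which span a modest range around compound 1. The step from compound 1 to compound 4 is expected to be small, with no clear direction and most likely none beyond the scatter, as given by a 1.1-fold higher number from compound 1 to compound 4 (0.02 log units; within the scatter). For compound 4 the estimate in this assay is 6000 nM, expected to fall between 2000 nM and 18000 nM.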

Compound 4, half-maximal effective concentration: 1720 nM
The estimate for compound 4 lay 3.5-fold (0.54 log units) above the measured number, and the stated range ends above it.
By their numbers in this assay, from the lowest: compounds 4, 2 and 1 (each within the scatter of the next, the first and the last beyond it); then compound 3.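

Among these compounds, with 3-(trifluoromethyl)benzyl in place of 4-chlorophenoxy on this aromatic carbon, this assay shows a 3.3-fold lower number from compound 1 to compound 4 (0.52 log units; beyond the scatter) as the first step that can be read at a single place. The position is therefore not indifferent to what it carries: the exchange of one aryl-bearing group for another moves the number beyond the scatter. No measurement on hand gives a reason for the step.

In this pair the linking oxygen, the ring substituent and its location on the ring all change together, so the compounds shown do not separate their contributions. Also open, from the compounds shown here alone, is how this carbon would read with a carboxylic acid, a morpholine or a longer alkyl chain in place of an aryl-bearing group.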